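From Isopropylamino to Dimethylamino on a Carbonyl Carbon

The source may hold more compounds than are shown below. What is called first, only, known or untested is meant among the compounds shown, and "the series" means these compounds.

In a functional assay on MDA-MB-468 cells (Homo sapiens) for antiproliferative activity, read by sulforhodamine B assay, with a stated time of 4 days (a lower number here means a stronger inhibitor of growth, a higher number a weaker inhibitor of growth), compound 1 (`COc1cc(Cl)c(-c2nc(SCC(=O)NC(C)C)nc3[nH]cc(C#N)c23)cc1O`) gives 178 nM, compound 2 (`CCOc1cc(-c2nc(SCC(=O)NC(C)C)nc3[nH]cc(C#N)c23)c(Cl)cc1OC`) gives 77 nM and compound 3 (`COc1cc(Cl)c(-c2nc(SCC(=O)NC(C)C)nc3[nH]cc(C#N)c23)cc1OC`) gives 102 nM. Compound 1 therefore carries the highest of the three numbers, although only its gap to compound 2 lies beyond the scatter: the data show a 2.3-fold lower number from compound 1 to compound 2 (0.36 log units; beyond the scatter), and also a 1.7-fold lower number from compound 1 to compound 3 (0.24 log units; within the scatter).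

Compound 4 (`COc1cc(Cl)c(-c2nc(SCC(=O)N(C)C)nc3[nH]cc(C#N)c23)cc1O`) keeps the core of compound 1 and differs at one place, with dimethylamino in place of isopropylamino on a carbonyl carbon.

For the measured compounds named here, none of the measured steps touches that place. All three are changes on an oxygen on an aromatic ring. The third, a 1.3-fold higher number from compound 2 to compound 3 (0.12 log units; within the scatter), is also small. They show only how far the numbers have moved among these compounds, so they offer a rough guide to size and no guide to direction. With no measurement at the carbonyl carbon, a small move toward a higher number in this assay is expected, and it may not clear the scatter. The expected step is a 1.4-fold higher number from compound 1 to compound 4 (0.15 log units; within the scatter). The estimated value for compound 4 is 250 nM, with an expected range of 80 nM to 750 nM.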

Compound 4, concentration for 50% growth inhibition: 23 nM
For compound 4 the middle estimate is 11-fold (1.04 log units) above the measured one, outside the stated range (below it).
By their numbers in this assay, from the lowest: compound 4; then compounds 2, 3 and 1 (each within the scatter of the next, the first and the last beyond it).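

In this assay the carbonyl carbon emerges as a place where the number can move well beyond the scatter, with a 7.7-fold lower number from compound 1 to compound 4 (0.89 log units; beyond the scatter) on changing isopropylamino to dimethylamino. For the compounds shown here, this single step is larger than any of the steps measured among compounds 1, 2 and 3, all of which were changes on an oxygen on an aromatic ring, so the earlier compounds gave no sign of a change this large. Isopropylamino counts 1 hydrogen-bond donor and dimethylamino 0, and the two also differ in their carbon groups, but this one pair cannot separate those differences, and no measurement at hand accounts for the size of the step.

The compounds shown leave open whether methylamino, which keeps the amide hydrogen, or morpholino on the same carbonyl carbon would give a number closer to that of compound 1 or to that of compound 4. They also leave open whether dimethylamino would have a step of similar size when paired with the ethoxy group of compound 2 or the second methoxy group of compound 3.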